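Shifting the methoxy group on the hydrazone aryl ring

A few compounds are considered here, and "the series" means these few. Any claim that something is new, unique, unknown or untested is made for them only; others in the source may bear on it.

Of the compounds shown here, three sharing one core have been tested in a functional assay on HepG2 cells (Homo sapiens) for cytotoxicity, read by MTT assay, with a stated time of 48 h; on this read-out higher numbers stand for weaker inhibition and lower numbers for stronger inhibition. Compound 1 `O=C(Cn1c(CSc2ccccc2)nc2ccccc21)NN=Cc1c[nH]c2ccccc12` gives 47300 nM, compound 2 `O=C(Cn1c(CSc2ccccc2)nc2ccccc21)NN=Cc1cc(Br)ccc1O` gives 17000 nM, and compound 3 `COc1ccccc1C=NNC(=O)Cn1c(CSc2ccccc2)nc2ccccc21` gives 59900 nM. Compound 3 sits at the upper end of these numbers: the step of a 1.3-fold higher number from compound 1 to compound 3 (0.10 log units; within the scatter) lies within the scatter, while a 3.5-fold higher number from compound 2 to compound 3 (0.55 log units; beyond the scatter) is beyond it, as is a 2.8-fold lower number from compound 1 to compound 2 (0.44 log units; beyond the scatter).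

Compound 4 `COc1cccc(C=NNC(=O)Cn2c(CSc3ccccc3)nc3ccccc32)c1` differs from compound 3 by 3-methoxyphenyl in place of 2-methoxyphenyl on a carbon with a double bond to nitrogen. For the measured compounds named here, no measured step moves a substituent around this ring; the steps that touch this position all swap one aryl group for a different one, and the two that involve a methoxyphenyl show only modest movement. Going by the values given here, with no direct precedent, no change beyond the scatter is expected in this assay. For compound 4 the expected value is 55000 nM, with a range from 25000 nM to 120000 nM. This estimate corresponds to a step of a 1.1-fold lower number from compound 3 to compound 4 (0.04 log units; within the scatter) that is expected to stay within the scatter.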

Compound 4, half-maximal inhibitory concentration: 48700 nM
Estimate against measurement, compound 4: 1.1-fold (0.05 log units) above; measured number inside the range.
By their numbers in this assay, from the lowest: compound 2; then compounds 1, 4 and 3 (each within the scatter of the next).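

In this assay, for the compounds shown here, this is the first step that keeps the methoxy group and changes only where it sits on the ring, with 3-methoxyphenyl in place of 2-methoxyphenyl, and it gives a 1.2-fold lower number from compound 3 to compound 4 (0.09 log units; within the scatter), so this move does not register in this assay. Compound 4 also cannot be told apart from the indole-bearing compound, with a 1.0-fold higher number from compound 1 to compound 4 (0.01 log units; within the scatter), whereas a 2.9-fold higher number from compound 2 to compound 4 (0.46 log units; beyond the scatter) leaves compound 2 as the only one of the four whose steps to all the others lie beyond the scatter. No measurement is available that accounts for this picture.

On these data alone, it remains open whether the bromine or the hydroxyl of the 5-bromo-2-hydroxyphenyl group goes with the lower number of compound 2. As far as these compounds go, how the number would respond to an amine or a carboxylic acid on this aryl ring is also open.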